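The compounds below may be only part of what the source reports. "The series", "measured", "known", "first", "only" and "open" are said of these compounds alone.

In a functional assay on HCT-116 cells (Homo sapiens) for cytotoxicity, read by sulforhodamine B assay, with a stated time of 24 h (on this read-out lower numbers stand for stronger inhibition and higher numbers for weaker inhibition), compound 1 (`N#CCC(=O)N/N=C1\C(=O)Nc2ccc(S(=O)(=O)N3CCOCC3)cc21`) gives 10300 nM as the lowest number, compound 2 (`CC(=O)N/N=C1\C(=O)Nc2ccc(S(=O)(=O)N3CCOCC3)cc21`) gives 29000 nM and compound 3 (`O=C1Nc2ccc(S(=O)(=O)N3CCOCC3)cc2/C1=N/c1ccc(C(=O)O)cc1`) gives 23600 nM on the same read-out. Compound 3 stands with compound 2 at the high end of these three numbers and clear of compound 1. Compound 4 (`O=C1Nc2ccc(S(=O)(=O)N3CCOCC3)cc2/C1=N/Nc1ccccc1`) brings anilino in place of 4-carboxyphenyl on a double-bonded nitrogen. On the steps of a 1.2-fold lower number from compound 2 to compound 3 (0.09 log units; within the scatter) and a 2.3-fold higher number from compound 1 to compound 3 (0.36 log units; beyond the scatter) at that same place, the first within the scatter and the second modest, no step beyond the scatter is expected in this assay for this change. The estimated step is a 1.5-fold lower number from compound 3 to compound 4 (0.17 log units; within the scatter) at most a slight drift. Compound 4 is expected at 16000 nM with an estimated range from 7000 nM to 35000 nM in this read-out.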

Compound 4, half-maximal inhibitory concentration: 10500 nM
For compound 4 the middle estimate is 1.5-fold (0.18 log units) above the measured one, within the range that was stated.
By their numbers in this assay, from the lowest: compounds 1 and 4 (each within the scatter of the next); then compounds 3 and 2 (each within the scatter of the next).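

In this assay, anilino on the double-bonded nitrogen improves on 4-carboxyphenyl, with a 2.2-fold lower number from compound 3 to compound 4 (0.35 log units; beyond the scatter), and phenyl in place of acetyl on an amine nitrogen gives a 2.8-fold lower number from compound 2 to compound 4 (0.44 log units; beyond the scatter). Phenyl in place of (cyanomethyl)carbonyl on that nitrogen gives a 1.0-fold higher number from compound 1 to compound 4 (0.01 log units; within the scatter), so the aromatic anilino matches the nitrile-bearing acyl chain at this position, and the series does not depend on that nitrile. No measurement available here explains these steps.

Open, as far as these compounds go, is whether an anilino ring carrying a carboxylic acid or a fluorine keeps this level. From the compounds shown here alone, the effect of a longer acyl chain on the amine nitrogen also remains open.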